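Ethylamino to dimethylamino: compound 3 to compound 4

The source may report more compounds than this note shows. Statements on the series, on what has been measured and on what is new or still open speak of the compounds shown alone.

In a functional assay on A549 cells (Homo sapiens) for antiproliferative activity, read by MTT assay, with a stated time of 48 h (a higher number here means a weaker inhibitor, a lower number a stronger inhibitor), compound 1 (`COc1ccc(C(=O)c2ccc3c(c2)C=CC(C)(C)O3)c(NC(=O)CBr)c1`) gives 1980 nM, compound 2 (`COc1ccc(C(=O)c2ccc3c(c2)C=CC(C)(C)O3)c(NC(=O)CN)c1`) gives 310 nM, and compound 3 (`CCNCC(=O)Nc1cc(OC)ccc1C(=O)c1ccc2c(c1)C=CC(C)(C)O2`) gives 1300 nM. Compound 3 thus stands level with the bromo compound, with a 1.5-fold lower number from compound 1 to compound 3 (0.18 log units; within the scatter). Amino in place of bromo gives a 6.4-fold lower number from compound 1 to compound 2 (0.81 log units; beyond the scatter), and ethyl in place of hydrogen on the amine nitrogen gives a 4.2-fold higher number from compound 2 to compound 3 (0.62 log units; beyond the scatter).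

Compound 4 (`COc1ccc(C(=O)c2ccc3c(c2)C=CC(C)(C)O3)c(NC(=O)CN(C)C)c1`) is next: dimethylamino in place of ethylamino on a saturated chain carbon bound to a carbonyl carbon. Dimethylamino replaces ethylamino on a saturated chain carbon bound to a carbonyl carbon, with the same atoms joined differently. Within the data shown here, no measured step makes this exchange directly. Among the measured compounds shown here, the closest evidence is a 4.2-fold higher number from compound 2 to compound 3 (0.62 log units; beyond the scatter), the only measured change on the amine nitrogen, and it suggests that a substituted amine may sit nearer compound 3 than compound 2. One step is thin support, so the range stays wide.

The estimate is a 1.4-fold lower number from compound 3 to compound 4 (0.16 log units; within the scatter), so no step beyond the scatter is expected. For compound 4 the expected value is 900 nM, with an estimated range of 350 nM to 2300 nM.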

Compound 4, half-maximal inhibitory concentration: 1160 nM
Estimate against measurement, compound 4: 1.3-fold (0.11 log units) below; low and high end bracket the measured number.
By their numbers in this assay, from the lowest: compound 2; then compounds 4, 3 and 1 (each within the scatter of the next).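

In this assay, a 1.1-fold lower number from compound 3 to compound 4 (0.05 log units; within the scatter) shows that exchanging ethylamino for dimethylamino at this position, on a saturated chain carbon bound to a carbonyl carbon, gives no step beyond the scatter, even though the hydrogen-bond donor counted on ethylamino is lost. With a 3.7-fold higher number from compound 2 to compound 4 (0.57 log units; beyond the scatter) beyond the scatter, a second substituted amine now parts from compound 2, so the earlier gap is no longer tied to ethylamino alone. a 1.7-fold lower number from compound 1 to compound 4 (0.23 log units; within the scatter) lies within the scatter, which leaves compound 2 as the strongest of the four and the only one clearly apart from the bromo compound. Nothing measured here accounts for this pattern.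

Still open, as far as these compounds go, is whether methylamino stays with compound 2 or joins compounds 3 and 4. From the compounds shown here alone, it is equally open where a ring amine such as morpholine or piperidine would fall.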